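The source may hold more compounds than are shown below. What is called first, only, known or untested is meant among the compounds shown, and "the series" means these compounds.

In a functional assay on U-937 cells (Homo sapiens) for antiproliferative activity, with a stated time of 48 h (a lower number here means that less compound is needed, a higher number that more compound is needed for the effect), compound 1 (`Nc1ccc(NC(=O)CCCCCCC(=O)NO)cc1`) gives 6400 nM while compound 2 (`O=C(CCCCCCC(=O)Nc1ccc(C(F)(F)F)cc1)NO`) gives 450 nM and compound 3 (`O=C(CCCCCCC(=O)Nc1ccc(Cl)cc1)NO`) gives 550 nM in the same read-out. Compound 3 stands level with compound 2 within the scatter and well apart from compound 1 (a 12-fold lower number from compound 1 to compound 3 (1.07 log units; beyond the scatter)). The next structure is compound 4 (`N#Cc1ccc(NC(=O)CCCCCCC(=O)NO)cc1`), which carries cyano in place of chloro on an aromatic carbon, para to a large group (cyano in place of chloro on an aromatic carbon). The large steps on replacing amino (a 14-fold lower number from compound 1 to compound 2 (1.15 log units; beyond the scatter) and a 12-fold lower number from compound 1 to compound 3 (1.07 log units; beyond the scatter)) bear only indirectly, since amino takes no part in this change. Within the data shown here, the closest precedent is the exchange of trifluoromethyl for chloro (a 1.2-fold higher number from compound 2 to compound 3 (0.09 log units; within the scatter)), which stayed within the scatter. Cyano has no measured precedent in the series, so this rests on a single comparison. No step beyond the scatter is therefore expected in this assay, and no direction is favoured. The estimated step is small (a 1.1-fold lower number from compound 3 to compound 4 (0.04 log units; within the scatter)). Compound 4 is expected at 500 nM (estimated range 200 nM to 1300 nM).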

Compound 4, half-maximal effective concentration: 7000 nM
For compound 4 the middle estimate is 14-fold (1.15 log units) below the measured one; measured number above the stated range.
By their numbers in this assay, from the lowest: compounds 2 and 3 (each within the scatter of the next); then compounds 1 and 4 (each within the scatter of the next).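

In this assay, the aromatic carbon para to a large group proves sensitive to the choice of group, which the exchange of trifluoromethyl for chloro did not reveal: cyano in place of chloro gives a 13-fold higher number from compound 3 to compound 4 (1.10 log units; beyond the scatter), and cyano in place of trifluoromethyl gives a 16-fold higher number from compound 2 to compound 4 (1.19 log units; beyond the scatter). Cyano in place of amino gives a 1.1-fold higher number from compound 1 to compound 4 (0.04 log units; within the scatter), so the four compounds form two pairs, with trifluoromethyl and chloro at the lower numbers and cyano and amino at the higher ones. Nothing available gives a reason for this grouping.

On these data alone, it remains open on which side of the gap groups such as bromo, methyl, methoxy or a carboxylic acid would fall at this position. As far as these compounds go, whether the same gap between the pairs holds with a longer chain is also open.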